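The source may hold more compounds than are shown below. What is called first, only, known or untested is meant among the compounds shown, and "the series" means these compounds.

Compound 1 `CC(=O)N1N=C(c2ccc3ccccc3c2)OC1c1ccccc1` is the starting point. In a functional assay on B16-F10 cells (Mus musculus) for antiproliferative activity, read by MTT assay, with a stated time of 48 h (on this read-out higher numbers stand for weaker inhibition and lower numbers for stronger inhibition), compound 1 gives 2.57 ug/mL. Two companions carry a chloro substituent on the phenyl group: compound 2 `CC(=O)N1N=C(c2ccc3ccccc3c2)OC1c1ccccc1Cl` gives 4.93 ug/mL, and compound 3 `CC(=O)N1N=C(c2ccc3ccccc3c2)OC1c1ccc(Cl)cc1` gives 2.48 ug/mL. Among these three numbers compound 1 stands second highest, yet every step from it lies within the scatter: a 1.9-fold higher number from compound 1 to compound 2 (0.28 log units; within the scatter) and a 1.0-fold lower number from compound 1 to compound 3 (0.02 log units; within the scatter). The move between the two chlorinated compounds is likewise small, a 2.0-fold lower number from compound 2 to compound 3 (0.30 log units; within the scatter).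

Compound 4 `CC(=O)N1N=C(c2ccc3ccccc3c2)OC1c1cccnc1` differs from compound 1 at the same saturated ring carbon, where the change is pyridin-3-yl in place of phenyl on a saturated ring carbon. Within the data shown here, no measured step exchanges the phenyl ring itself; the steps from compound 1 to compound 2 and from compound 1 to compound 3 only decorate that ring, and each stays within the scatter. Nothing in these data therefore points to a move beyond the scatter in either direction. The step from compound 1 to compound 4 is estimated at a 1.1-fold higher number from compound 1 to compound 4 (0.02 log units; within the scatter). Compound 4 is expected to give 2.7 ug/mL, likely between 1.2 ug/mL and 6.5 ug/mL.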

Compound 4, half-maximal inhibitory concentration: 3.06 ug/mL
Beside the measured number, compound 4's estimate is 1.1-fold (0.05 log units) below it; measured number inside the range.
By their numbers in this assay, from the lowest: compounds 3, 1, 4 and 2 (each within the scatter of the next).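

The earlier compounds shown here only decorated the phenyl ring, whereas compound 4 exchanges the ring itself for pyridin-3-yl, and in this assay that exchange stays within the scatter, with a 1.2-fold higher number from compound 1 to compound 4 (0.08 log units; within the scatter). Set against the chlorinated compounds the picture is the same, with a 1.2-fold higher number from compound 3 to compound 4 (0.09 log units; within the scatter) and a 1.6-fold lower number from compound 2 to compound 4 (0.21 log units; within the scatter), so this read-out cannot tell the four aromatic groups shown on this saturated ring carbon apart. No measurement is available here that would explain this result.

The compounds shown leave open whether the same holds for a saturated cyclohexyl ring at this carbon, or for a phenyl ring carrying an amine or a carboxylic acid. They also leave open whether a longer chain in place of the acetyl group would shift the number beyond the scatter.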